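Amine replacement series on the shared core, oxytocin receptor binding

This account rests on a few compounds, and the source may have more. Where it says the series, first, only, none or still open, it means among the compounds named here.

Measured so far:
compound 1 `Cc1ccccc1N1CCN(S(=O)(=O)C[C@]23CCC(C[C@@H]2NC(=O)[C@H](CCS(C)(=O)=O)NC2CCS(=O)(=O)CC2)C3(C)C)CC1`: 1.4 nM
compound 2 `Cc1ccccc1N1CCN(S(=O)(=O)C[C@]23CCC(C[C@@H]2NC(=O)[C@H](CCS(C)(=O)=O)NC2CCNCC2)C3(C)C)CC1`: 1.3 nM

In an assay on isolated protein for displacement of a labelled ligand from Oxytocin receptor (Rattus norvegicus) (on this read-out higher numbers stand for weaker inhibition and lower numbers for stronger inhibition), compound 2 gives 1.3 nM, the lower of the two numbers, with compound 1 within the scatter of it. Going by the values given here, the only step measured, a 1.1-fold lower number from compound 1 to compound 2 (0.03 log units; within the scatter), exchanges one ring on the amine nitrogen for another without moving the number beyond the scatter.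

Compound 3 `Cc1ccccc1N1CCN(S(=O)(=O)C[C@]23CCC(C[C@@H]2NC(=O)[C@H](CCS(C)(=O)=O)N(C)C)C3(C)C)CC1` is not yet measured. It differs from compound 2 by dimethylamino in place of (piperidin-4-yl)amino on a saturated chain carbon bound to a carbonyl carbon and a saturated chain carbon. Among the compounds with values here, the one measured step bears on this change only loosely, since it swaps ring for ring while here the ring is dropped and the amine becomes fully substituted. Given that the amine substituent was tolerated in a 1.1-fold lower number from compound 1 to compound 2 (0.03 log units; within the scatter), a step of a 1.9-fold higher number from compound 2 to compound 3 (0.28 log units; within the scatter) is expected in this assay, most likely within the scatter or a mild weakening. For compound 3 the estimate is 2.5 nM, with a range from 0.8 nM to 8 nM.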

Compound 3, half-maximal inhibitory concentration: 4.9 nM
The estimate for compound 3 lay 2.0-fold (0.29 log units) below the measured number; the measured number falls inside the stated range.
By their numbers in this assay, from the lowest: compounds 2 and 1 (each within the scatter of the next); then compound 3.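

In this assay, the ring-for-ring swap left the number within the scatter, but removing the ring from this saturated chain carbon moves it beyond the scatter, whether dimethylamino replaces (piperidin-4-yl)amino (a 3.8-fold higher number from compound 2 to compound 3 (0.58 log units; beyond the scatter)) or (1,1-dioxothian-4-yl)amino (a 3.5-fold higher number from compound 1 to compound 3 (0.54 log units; beyond the scatter)). Both steps are modest, so a ring on the amine nitrogen is not required for binding at this level, although compounds 1 and 2 both sit lower than compound 3. No measurement on hand accounts for this shift.

The ring and the second methyl-type substitution change together in these steps, so their contributions cannot be separated. A methylamino group would test the fully substituted amine, and a piperidin-1-yl or cyclohexylamino group would test the ring.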